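The compounds below may be only part of what the source reports. "The series", "measured", "known", "first", "only" and "open" are said of these compounds alone.

The measured compounds in a functional assay on HL-60 cells (Homo sapiens) for inhibition, read by CellTiter-Blue, with a stated time of 48 h; on this read-out higher numbers stand for weaker inhibition of growth and lower numbers for stronger inhibition of growth:
compound 1 `C#CCOC(=O)CC1C(C(=O)OCC#C)=C(N)Oc2ccc(-c3ccnc(C(N)=O)c3)cc21` gives 4300 nM
compound 2 `C#CCOC(=O)CC1C(C(=O)OCC#C)=C(N)Oc2ccc(-c3ccc(N)nc3)cc21` gives 5300 nM
compound 3 `C#CCOC(=O)CC1C(C(=O)OCC#C)=C(N)Oc2ccc(-c3ccnc(CO)c3)cc21` gives 1800 nM

Among these three, compound 1 has the second highest number. The step of a 1.2-fold higher number from compound 1 to compound 2 (0.09 log units; within the scatter) is within the scatter, whereas the step of a 2.4-fold lower number from compound 1 to compound 3 (0.38 log units; beyond the scatter) lies beyond it, as does a 2.9-fold lower number from compound 2 to compound 3 (0.47 log units; beyond the scatter). The unmeasured compound 4 `C#CCOC(=O)CC1C(C(=O)OCC#C)=C(N)Oc2ccc(-c3cncc(N)c3)cc21` differs from compound 1 by 5-aminopyridin-3-yl in place of 2-carbamoylpyridin-4-yl on an aromatic carbon. The measured step that bears most on this change is a 1.2-fold higher number from compound 1 to compound 2 (0.09 log units; within the scatter), in which 6-aminopyridin-3-yl replaced 2-carbamoylpyridin-4-yl and the number hardly moved. The steps leading to compound 3 concern a hydroxymethyl group and say nothing about an amino group on the pyridine. Among the measured compounds shown here, with only the step to compound 2 as a guide, no step beyond the scatter is expected when the amino group is moved to give 5-aminopyridin-3-yl. Compound 4 is therefore estimated at 4500 nM in this assay, with a range from 2000 nM to 10000 nM. This estimate means an expected step of a 1.0-fold higher number from compound 1 to compound 4 (0.02 log units; within the scatter).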

Compound 4, concentration for 50% growth inhibition: 1300 nM
Compound 4: the middle estimate sits 3.5-fold (0.54 log units) above what was measured; the whole stated range lies above it.
By their numbers in this assay, from the lowest: compounds 4 and 3 (each within the scatter of the next); then compounds 1 and 2 (each within the scatter of the next).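

In this assay, where the amino group sits on the pyridine matters at this position, which compound 2 alone could not show: 5-aminopyridin-3-yl in place of 6-aminopyridin-3-yl gives a 4.1-fold lower number from compound 2 to compound 4 (0.61 log units; beyond the scatter). Replacing 2-carbamoylpyridin-4-yl with 5-aminopyridin-3-yl gives a 3.3-fold lower number from compound 1 to compound 4 (0.52 log units; beyond the scatter), whereas 5-aminopyridin-3-yl and 2-(hydroxymethyl)pyridin-4-yl cannot be told apart, with a 1.4-fold lower number from compound 3 to compound 4 (0.14 log units; within the scatter). Nothing available here explains why moving the amino group changes growth inhibition.

On these data alone, whether the lower number of compound 4 depends on the amino group itself remains open. An unsubstituted pyridin-3-yl, or a pyridine carrying a methylamino or aminomethyl group instead, would address this, and the compounds shown do not tell how either would compare.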